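Fluoro removal in the fluorophenyl series

The source may report more compounds than this note shows. Statements on the series, on what has been measured and on what is new or still open speak of the compounds shown alone.

- compound 1 `Cn1nc(-c2ccc(F)cc2F)n(C)c1=S`: 1 mg/kg
- compound 2 `CCn1c(-c2ccccc2)nn(C)c1=S`: 0.58 mg/kg
- compound 3 `Cn1nc(-c2ccc(F)cc2)n(C)c1=S`: 0.61 mg/kg

All values come from a functional assay on the whole organism with Mus musculus as the target; a higher number here means that more compound is needed for the effect, a lower number that less compound is needed. Compound 1 lies within the scatter of both compound 2 and compound 3, so no order can be read among the three. Compound 4 `Cn1nc(-c2ccccc2F)n(C)c1=S` differs from compound 1 by hydrogen in place of fluoro on an aromatic carbon, para to a group of 8 heavy atoms. Within the data shown here, the one measured step of this kind replaces the other fluoro group of compound 1: a 1.6-fold lower number from compound 1 to compound 3 (0.21 log units; within the scatter). On that single step, no change beyond the scatter is expected in this assay. The estimated step is a 1.4-fold lower number from compound 1 to compound 4 (0.15 log units; within the scatter). Compound 4 is expected at 0.7 mg/kg, within an estimated range of 0.35 mg/kg to 1.4 mg/kg.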

Compound 4, dose for half-maximal effect: 0.74 mg/kg
Compound 4: the middle estimate sits 1.1-fold (0.02 log units) below what was measured; the measured number falls inside the stated range.
By their numbers in this assay, from the lowest: compounds 2, 3, 4 and 1 (each within the scatter of the next).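

In this assay the fluoro group para to a group of 8 heavy atoms gives way to hydrogen with no change beyond the scatter, a 1.4-fold lower number from compound 1 to compound 4 (0.13 log units; within the scatter). Alongside a 1.6-fold lower number from compound 1 to compound 3 (0.21 log units; within the scatter), each of the two fluoro groups of compound 1 has now been replaced singly, and neither step leaves the scatter. Nothing available explains this result. Still open, on these data alone, is whether the number holds with both fluoro groups replaced by hydrogen, and whether a larger group at this position, such as methoxy or an amine, would shift it.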